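Amine Alkyl Change on the Shared Core, Compound 2 to 3

The source may report more compounds than this note shows. Statements on the series, on what has been measured and on what is new or still open speak of the compounds shown alone.

Compound 1 `CN(C)Cc1ccc2nc(NC(=O)N/N=C/c3ccccn3)sc2c1` sits at a limit of the assay: in a functional assay on MCF7 cells (Homo sapiens) for antiproliferative activity, read by CCK-8 assay, with a stated time of 24 h (on this read-out higher numbers stand for weaker inhibition and lower numbers for stronger inhibition), compound 1 reads > 40000 nM, which is a limit and not a number, as recorded in the limit of > 40000 nM in this assay, at which 1 of the 2 values shown sits. Among the measured compounds shown here, compound 2 `CN(C)Cc1ccc(NC(=O)NN=C(c2ccccc2)c2ccccc2)cc1` is the only member with a finite value, and in this assay compound 2 gives 12100 nM. Compound 3 `CCN(CC)Cc1ccc(NC(=O)NN=C(c2ccccc2)c2ccccc2)cc1` has not been measured; it differs from compound 2 by diethylamino in place of dimethylamino on a saturated chain carbon bound to an aromatic carbon. For the measured compounds named here, no measured pair covers this change, so no direction can be read from the series. The expected step from compound 2 to compound 3 in this assay is a 1.1-fold lower number from compound 2 to compound 3 (0.04 log units; within the scatter), no larger than the usual scatter. Compound 3 is therefore estimated at 11000 nM, with a range from 4000 nM to 32000 nM.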

Compound 3, half-maximal inhibitory concentration: 13100 nM
Compound 3: the middle estimate sits 1.2-fold (0.08 log units) below what was measured, and the stated range covers the measured number.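

Among the compounds shown here, this is the first measured step at this place, on a saturated chain carbon bound to an aromatic carbon: in this assay, diethylamino in place of dimethylamino gives a 1.1-fold higher number from compound 2 to compound 3 (0.03 log units; within the scatter). The change from (dimethylamino)methyl to (diethylamino)methyl therefore stays within the scatter, and the two amines cannot be told apart on this read-out. No measured property among the data shown bears on this step.

Going by these compounds, whether a ring amine such as pyrrolidine or morpholine, or a primary amine, at this place would move the number beyond the scatter remains open. Compound 1 reads > 40000 nM, which is a limit and not a number, so it adds no readable step to this comparison.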